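The compounds below may be only part of what the source reports. "The series", "measured", "known", "first", "only" and "open" are said of these compounds alone.

The measured compounds are compound 1 `CS/C(=N\C(=O)c1cc(-c2ccccc2)nc2ccccc12)NC(=O)c1cc(-c2ccccc2)nc2ccccc12`, compound 2 `C[Se]/C(=N\C(=O)c1cnc2ccccc2c1)NC(=O)c1cnc2ccccc2c1` and compound 3 `O=C(/N=C(/NC(=O)c1csc([N+](=O)[O-])c1)[Se]Cc1ccccc1)c1csc([N+](=O)[O-])c1`.

In a functional assay on HT-29 cells (Homo sapiens) for cytotoxicity, read by MTT assay, with a stated time of 72 h (a higher number here means a weaker inhibitor of growth, a lower number a stronger inhibitor of growth), compound 1 gives 23700 nM, the highest of the three numbers. Compound 3 comes nearest with 9250 nM, and compound 2 lies furthest away with 200 nM; both of those gaps lie beyond the usual scatter. Compound 2 and compound 3 each carry selenium where compound 1 carries sulfur, but they also have different cores, so no single change among the measured compounds can be isolated.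

Compound 4 `O=C(/N=C(/NC(=O)c1cc(-c2ccccc2)nc2ccccc12)[Se]Cc1ccccc1)c1cc(-c2ccccc2)nc2ccccc12` keeps the core of compound 1 and differs from it only in one place: a group of 8 heavy atoms (7 carbon, 1 selenium; one six-membered aromatic ring of carbon only) in place of a group of 2 heavy atoms (1 carbon, 1 sulfur; no ring), on a carbon with a double bond to nitrogen. The group entering, with its selenium and its six-membered aromatic ring of carbon only, resembles the selenium-bearing groups of compound 2 and compound 3, which sit at lower numbers in this assay. A moderate step downward is therefore expected, a 3.0-fold lower number from compound 1 to compound 4 (0.47 log units; beyond the scatter), probably beyond the scatter but well short of the number seen for compound 2. Compound 4 is estimated at 8000 nM, within a range from 2000 nM to 30000 nM.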

Compound 4, concentration for 50% growth inhibition: 6070 nM
The estimate for compound 4 lay 1.3-fold (0.12 log units) above the measured number; low and high end bracket the measured number.
By their numbers in this assay, from the lowest: compound 2; then compounds 4 and 3 (each within the scatter of the next); then compound 1.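

Among the compounds shown here, replacing methylsulfanyl with the larger selenium group on the carbon with a double bond to nitrogen gives, in this assay, a 3.9-fold lower number from compound 1 to compound 4 (0.59 log units; beyond the scatter), the first reading of a change in one place, and it shows that the number responds to this position on the core of compound 1. The step is modest, and it combines two differences: selenium for sulfur, and a six-membered aromatic ring of carbon only that methylsulfanyl lacks. Nothing available bears on why the number falls.

The compounds shown do not separate the part played by selenium from that played by the ring, and a methyl group on selenium on this same core would address this. On these data alone, how an amine or a longer chain on sulfur would read at this carbon also stays open.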